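One stereocentre inverted: what to expect of compound 3

The source may hold more compounds than are shown below. What is called first, only, known or untested is meant among the compounds shown, and "the series" means these compounds.

Among the measured compounds shown here, in a functional assay on MCF7 cells (Homo sapiens) for antiproliferative activity, read by MTT assay, with a stated time of 48 h (a lower number here means a stronger inhibitor, a higher number a weaker inhibitor), compound 1 (`CCCCCCCCCCn1cc(COC[C@@H]2OC[C@H](N)[C@@H]2O)nn1`) gives 9640 nM and compound 2 (`CCCCCCCCCCCCCCCCCCn1cc(COC[C@@H]2OC[C@H](N)[C@@H]2O)nn1`) gives 7580 nM as the only two numbers so far. Compound 1 therefore stands level with compound 2, the two values lying within the scatter of each other.

The change to compound 3 (`CCCCCCCCCCn1cc(COC[C@@H]2OC[C@H](N)[C@H]2O)nn1`) is purely one of configuration (the two compounds have the same atoms and bonds and differ only in configuration as drawn: 1 of 3 stereo elements differ; a stereocentre at a saturated ring carbon is drawn S in compound 1 and R in compound 3): a stereocentre at a saturated ring carbon is drawn S in compound 1 and R in compound 3.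

For the measured compounds named here, the single measured step (a 1.3-fold lower number from compound 1 to compound 2 (0.10 log units; within the scatter)) concerns the chain and not configuration, so it bears on this change only indirectly. Going by the values given here, no measured pair tests a stereocentre inversion, and the data give neither a size nor a direction for one. With compound 1 at 9640 nM as the sole anchor, no shift beyond the scatter is expected, but the range is kept wide to reflect the missing evidence. The expected step (a 1.1-fold lower number from compound 1 to compound 3 (0.03 log units; within the scatter)) is accordingly no more than a nominal one. Compound 3 is estimated at 9000 nM with an expected range of 4000 nM to 20000 nM for now.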

Compound 3, half-maximal inhibitory concentration: 45000 nM
Beside the measured number, compound 3's estimate is 5.0-fold (0.70 log units) below it; measured number outside the range, above it.
By their numbers in this assay, from the lowest: compounds 2 and 1 (each within the scatter of the next); then compound 3.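

Inverting the stereocentre at a saturated ring carbon from S to R gives a 4.7-fold higher number from compound 1 to compound 3 (0.67 log units; beyond the scatter) in this assay, the only step in the series so far that lies beyond the scatter. The chain change, by contrast, gave a 1.3-fold lower number from compound 1 to compound 2 (0.10 log units; within the scatter), so the read-out responds to configuration at this one carbon, while the chain extension shown leaves it within the scatter. The shift can be assigned to this inversion alone because nothing else separates the pair: the fact that compounds 1 and 3 differ only in the configuration as drawn

As far as these compounds go, it remains open whether the inversion has a step of similar size on the longer chain of compound 2, and whether the other two stereo elements of the core matter as much as this one. Also open is how the S and R forms would compare once the amine is replaced by an acetamide or the hydroxyl by a methyl ether, since the compounds shown carry only the free amine and free hydroxyl.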